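From compound 2 to the cyclopropyl amide compound 3

This account rests on a few compounds, and the source may have more. Where it says the series, first, only, none or still open, it means among the compounds named here.

Compound 1 `CN1C[C@H](C(=O)Nc2ccc(F)cc2)[C@@H](c2ccc(/C=C/C(=O)Nc3ccccc3N)cc2)C1` gives 5 mL/min/kg
Compound 2 `Cc1cc(NC(=O)[C@H]2CN(C)C[C@@H]2c2ccc(/C=C/C(=O)Nc3ccccc3N)cc2)ccc1Cl` gives 15 mL/min/kg

Both compounds were tested in an in vitro ADME assay on microsomes from liver (Homo sapiens) for pharmacokinetics, read by LC-MS, with a stated time of 10 min, tested at 1 uM (on this read-out lower numbers stand for slow clearance and higher numbers for fast clearance),  and compound 2 stands highest of the two (15 mL/min/kg). Compound 3 `CN1C[C@H](C(=O)NC2CC2)[C@@H](c2ccc(/C=C/C(=O)Nc3ccccc3N)cc2)C1` differs from compound 2 in one place (cyclopropyl in place of 4-chloro-3-methylphenyl on an amide-type nitrogen), on an amide-type nitrogen. For the measured compounds named here, only one measured step bears on this change, and it sits on the same nitrogen: 4-chloro-3-methylphenyl in place of 4-fluorophenyl gave a 3.0-fold higher number from compound 1 to compound 2 (0.48 log units; beyond the scatter), a modest step. Going by the values given here, removing the 4-chloro-3-methylphenyl group is therefore expected to lower the number by a similar modest amount, though no measured compound carries cyclopropyl, so the size remains uncertain. The expected change is a 2.5-fold lower number from compound 2 to compound 3 (0.40 log units; beyond the scatter), which would bring the number back towards the low end of the pair. In this assay,  compound 3 is estimated at 6 mL/min/kg (expected range 2.5 mL/min/kg to 14 mL/min/kg).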

Compound 3, clearance: 10 mL/min/kg
Compound 3: middle estimate off by 1.7-fold (0.22 log units), on the low side, and the stated range covers the measured number.
By their numbers in this assay, from the lowest: compounds 1, 3 and 2 (each within the scatter of the next, the first and the last beyond it).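

In this assay, cyclopropyl in place of 4-chloro-3-methylphenyl on the amide-type nitrogen gave a 1.5-fold lower number from compound 2 to compound 3 (0.18 log units; within the scatter), and cyclopropyl in place of 4-fluorophenyl gave a 2.0-fold higher number from compound 1 to compound 3 (0.30 log units; within the scatter). For the compounds shown here, a three-membered non-aromatic ring of carbon only can thus stand on this nitrogen in place of either six-membered aromatic ring without a step beyond the scatter, and the only such step among the three remains a 3.0-fold higher number from compound 1 to compound 2 (0.48 log units; beyond the scatter). No measurement at hand accounts for these numbers.

As far as these compounds go, how an open alkyl chain, an amine or a carboxylic acid on this nitrogen would read in this assay remains open. From the compounds shown here alone, all three compounds share the rest of the structure, so whether these exchanges would read the same way on a different core also remains open.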